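The compounds below may be only part of what the source reports. "The series", "measured", "known", "first", "only" and "open" are said of these compounds alone.

Compound 1, with structure `CCCc1ccc(C(=O)Nc2cc3nc(C4CCCCC4)[nH]c3cc2N(C)C)cc1`, is known only as a limit in an ADME assay on Vero cells (Chlorocebus sabaeus) for cytotoxicity, read by resazurin assay, with a stated time of 3 days; a lower number here means a stronger inhibitor, a higher number a weaker inhibitor: compound 1 gives > 100 ug/mL, which is a limit of the assay rather than a number. Compound 2, `CN(C)c1cc2[nH]c(C3CCCCC3)nc2cc1NC(=O)OCc1ccccc1`, likewise gives > 100 ug/mL in this assay, again a limit. Compound 3, `CCCc1ccc(C(=O)Nc2cc3nc(C4CCCCC4)[nH]c3cc2N(CC)CC)cc1`, has no result in this assay: "not determined" (no result reported). Within the data shown here, the one measured step, a step that the two limits leave unreadable from compound 1 to compound 2, cannot be read because both values sit at the limit of > 100 ug/mL in this assay, at which 2 of the 3 values shown sit. Compound 4 has the structure `CN(C)c1cc2[nH]c(C3CCCCC3)nc2cc1NC(=O)c1ccc(OC(F)(F)F)cc1`; the change from compound 1 is trifluoromethoxy in place of propyl on an aromatic carbon. Among the measured compounds shown here, no measured step bears on this change, so the expected step is a number no higher from compound 1 to compound 4 (the limit leaves the size open), nothing beyond the scatter. Compound 4 is therefore estimated to give about 100 ug/mL, within 50 ug/mL to 200 ug/mL, most likely reported again only as a limit.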

Compound 4, half-maximal inhibitory concentration: > 100 ug/mL
Compound 4 gave a limit, no number (the forecaster's own chance of this, stated with the estimate: 70%); the middle value lies on the limit itself.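

No step can be read from compound 1 to compound 4, because both values are limits and not numbers: the limit of > 100 ug/mL in this assay, at which 3 of the 4 values shown sit. The compounds shown leave open the actual values of compound 1, compound 2 and compound 4, and whether trifluoromethoxy in place of propyl changes anything.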